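The source may hold more compounds than are shown below. What is called first, only, known or untested is meant among the compounds shown, and "the series" means these compounds.

Values in a functional assay on KYSE-410 cells (Homo sapiens) for antiproliferative activity, read by MTT assay, with a stated time of 72 h; a higher number here means a weaker inhibitor, a lower number a stronger inhibitor:
- compound 1 `O=C(Nc1cccc(F)c1)c1cc(=O)[nH]c2cc(-c3ccc(F)cc3)ccc12`: 10300 nM
- compound 2 `O=C(Nc1cccc(F)c1)c1cc(=O)[nH]c2cc(-c3ccsc3)ccc12`: 4300 nM
- compound 3 `O=C(Nc1cccc(F)c1)c1cc(=O)[nH]c2cc(-c3ccncc3)ccc12`: > 20000 nM, a limit

Compound 3 has no number, only this limit. Compound 4 `O=C(Nc1cccc(F)c1)c1cc(=O)[nH]c2cc(-c3ccc(F)nc3)ccc12` carries 6-fluoropyridin-3-yl in place of pyridin-4-yl on an aromatic carbon. The nearest measured changes are ring swaps at that same carbon: a 2.4-fold lower number from compound 1 to compound 2 (0.38 log units; beyond the scatter), an at least 1.9-fold higher number from compound 1 to compound 3 (0.28 log units; that floor lies within the scatter) and an at least 4.6-fold higher number from compound 2 to compound 3 (0.66 log units; beyond the scatter). These steps are modest or bounded only by a floor, so a modest move to a lower number is expected. The closest comparison is compound 1 at 10300 nM, which also has a fluorinated six-membered ring. The expected change is an at least 1.6-fold lower number from compound 3 to compound 4 (0.22 log units; that floor lies within the scatter). The estimate for compound 4 is 12000 nM, with an expected range of 5000 nM to 25000 nM.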

Compound 4, half-maximal inhibitory concentration: > 20000 nM
Compound 4 gave a limit, no number (the forecaster's own chance of this, stated with the estimate: 30%); at least 1.6-fold (0.22 log units) between middle value and limit.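

Compound 4 ends at a limit, not a number: > 20000 nM. At this aromatic carbon, 6-fluoropyridin-3-yl in place of thiophen-3-yl gives an at least 4.6-fold higher number from compound 2 to compound 4 (0.66 log units; beyond the scatter), while in place of 4-fluorophenyl it gives an at least 1.9-fold higher number from compound 1 to compound 4 (0.28 log units; that floor lies within the scatter). The step from compound 3 to compound 4 cannot be read, because both compounds stop at the same limit: the limit of > 20000 nM in this assay, at which 2 of the 4 values shown sit.

Open, as far as these compounds go, is how a pyridin-3-yl ring without fluorine would read at this carbon. Also open, from the compounds shown here alone, is whether an amine or a methoxy group in place of that fluorine would bring a measurable value.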